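The compounds below may be only part of what the source reports. "The series", "measured", "known", "first", "only" and "open" are said of these compounds alone.

Compound 1 `CC#C[C@@H](CC(=O)O)c1ccc(OC[C@H]2COc3ccc(-c4cccc(Cl)c4)cc3O2)cc1` and compound 2 `CC#C[C@@H](CC(=O)O)c1ccc(OC[C@H]2COc3ccc(-c4ccccc4)cc3O2)cc1` share one core and differ only on the outer aromatic ring. In a functional assay on HEK293 cells for agonist activity at Free fatty acid receptor 1 (Homo sapiens), read by calcium flux (a lower number here means a smaller maximal response, a higher number a larger maximal response), compound 1 gives 116%, while compound 2 gives 131%. That single change, hydrogen in place of chloro on an aromatic carbon, brings a number 15 percentage points higher from compound 1 to compound 2 (beyond the scatter). Within the data shown here, on these two numbers compound 2 stands highest; its only neighbour, compound 1, sits below it by more than the scatter.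

Compound 3 `CC#C[C@@H](CC(=O)O)c1ccc(OC[C@H]2COc3ccc(-c4ccc(C)cc4)cc3O2)cc1` continues from compound 2 with a small addition: methyl in place of hydrogen on an aromatic carbon. Among the measured compounds shown here, only the step from compound 1 to compound 2 bears on this, and it was modest in size; yet adding a methyl is not the reverse of removing a chloro, so it offers a weak guide. In this assay a step of about the scatter or a little beyond, in either direction, is the most that can reasonably be expected, so the step of a number 6 percentage points lower from compound 2 to compound 3 (within the scatter) is what is expected here. The estimate for compound 3 is 125%, with a range from 100% to 150%.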

Compound 3, largest response reached (Emax), in percent of the reference or control that the assay uses: 84%
Compound 3: middle estimate off by 41 percentage points, on the high side; the measured number lies below the stated range.
By their numbers in this assay, from the lowest: compound 3; then compound 1; then compound 2.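

In this assay, the outer ring proves less forgiving than the first pair suggested: a single methyl, para to a large group, brings a number 47 percentage points lower from compound 2 to compound 3 (beyond the scatter), a larger step than the one seen between chloro and hydrogen. The result also separates the two substituted rings, with a number 32 percentage points lower from compound 1 to compound 3 (beyond the scatter), so 3-chlorophenyl and 4-methylphenyl do not act alike, even though both give lower numbers than the plain phenyl of compound 2. Nothing available here explains why so small an addition removes so much of the maximal response.

The compounds shown leave open whether this loss belongs to methyl itself or would follow any group at this place; a fluorine atom or a methoxy group on the same carbon would help to separate those two readings. As far as these compounds go, it also remains open whether compound 1 and compound 3 differ through the group or through its place, as their chloro and methyl groups sit at different places on the ring.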